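This account rests on a few compounds, and the source may have more. Where it says the series, first, only, none or still open, it means among the compounds named here.

Measured compounds:
compound 1 `N#Cc1ccc(C2OCC(C/C=C\CCC(=O)O)C(c3cccnc3)O2)cc1`, 24 nM;
compound 2 `O=C(O)CC/C=C\CC1COC(c2ccc3ccccc3c2)OC1c1cccnc1`, 50 nM;
compound 3 `Cc1ccc(OC(C)(C)C2OCC(C/C=C\CCC(=O)O)C(c3cccnc3)O2)cc1`, 360 nM.

All three share one core and were tested in an assay for inhibition of Thromboxane-A synthase (Homo sapiens), using microsomes; a higher number here means a weaker inhibitor, a lower number a stronger inhibitor. Compound 3 gives the highest number of the three, so it is the weakest inhibitor among them, with compound 2 nearest and compound 1 furthest below it. Compound 4 `CC(C)(Sc1ccccc1)C1OCC(C/C=C\CCC(=O)O)C(c2cccnc2)O1` has not been measured. It differs from compound 3 in one place: phenylsulfanyl in place of 4-methylphenoxy on a saturated chain carbon bound to two saturated chain carbons and a saturated ring carbon.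

Among the measured compounds shown here, the single measured step, a 2.1-fold higher number from compound 1 to compound 2 (0.32 log units; beyond the scatter), concerns a change on a saturated ring carbon, not the chain carbon altered here, so it does not bear directly on this step. For the measured compounds named here, there is no measured example of the group change itself, and its size or direction is not known from these data. The expectation therefore rests on compound 3 alone, with a wide range around its value, and the step of a 1.2-fold lower number from compound 3 to compound 4 (0.08 log units; within the scatter) is expected to stay modest. Compound 4 is estimated at 300 nM in this assay, between 90 nM and 1000 nM.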

Compound 4, half-maximal inhibitory concentration: 40 nM
For compound 4 the middle estimate is 7.5-fold (0.88 log units) above the measured one, and the stated range ends above it.
By their numbers in this assay, from the lowest: compounds 1, 4 and 2 (each within the scatter of the next, the first and the last beyond it); then compound 3.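

In this assay, the chain carbon bound to two saturated chain carbons and a saturated ring carbon proves sensitive: phenylsulfanyl in place of 4-methylphenoxy gives a 9.0-fold lower number from compound 3 to compound 4 (0.95 log units; beyond the scatter), although both groups carry one six-membered aromatic ring of carbon only. The new compound also falls within the scatter of the two compounds with a different group on the saturated ring carbon, with a 1.3-fold lower number from compound 2 to compound 4 (0.10 log units; within the scatter) and a 1.7-fold higher number from compound 1 to compound 4 (0.22 log units; within the scatter). No measured information on these compounds offers an explanation for the large step.

This change replaces oxygen with sulfur and also removes a methyl group, so the data cannot show which of the two matters. Phenoxy and 4-methylphenylsulfanyl at this position would separate them, while an amine there remains an open case.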